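The compounds below may be only part of what the source reports. "The series", "measured", "known", "first", "only" and "open" are said of these compounds alone.

Measured compounds in a functional assay on HL-60 cells (Homo sapiens) for antiproliferative activity, read by sulforhodamine B assay, with a stated time of 72 h; on this read-out higher numbers stand for weaker inhibition and lower numbers for stronger inhibition:

- compound 1 `NC(=S)N/N=C/c1cc2cccnc2s1` gives > 100000 nM
- compound 2 `S=C(NCc1ccccc1)N/N=C/c1ccc2ccccc2n1` gives 21900 nM
- compound 3 `NC(=S)N/N=C/c1ccc2cccnc2n1` gives > 100000 nM

Of these three results, only compound 2 has an actual number. For compound 1 the value of > 100000 nM is a limit of the assay, not a measured number. For compound 3 the value of > 100000 nM is likewise a limit of the assay. Going by the values given here, compound 2 therefore stands alone as the one compound with a quantified result, while the other two sit at the limit of > 100000 nM in this assay, at which 2 of the 3 values shown sit. Among the compounds with values here, no two measured compounds differ in a single place, so no measured step is available to guide expectations.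

Compound 4 `S=C(N/N=C/c1ccc2ccccc2n1)Nc1cccc(Cl)c1` keeps the core of compound 2 and changes one substituent: 3-chlorophenyl in place of benzyl on an amide-type nitrogen. Both groups carry the same number of heavy atoms and the same single aromatic ring, and neither adds or removes a hydrogen-bond donor or acceptor. Without any measured step of this kind, the expected change in this assay from compound 2 to compound 4 is small, in no firm direction, and likely within the scatter: a 1.2-fold lower number from compound 2 to compound 4 (0.09 log units; within the scatter). Compound 4 is accordingly estimated at 18000 nM, with a range from 5000 nM to 70000 nM.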

Compound 4, half-maximal inhibitory concentration: 28800 nM
For compound 4 the middle estimate is 1.6-fold (0.20 log units) below the measured one; the measured number falls inside the stated range.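

Going by these compounds alone, the step of a 1.3-fold higher number from compound 2 to compound 4 (0.12 log units; within the scatter) in this assay is the first one-place comparison in this set, and it concerns the group on the amide-type nitrogen whose other neighbour is the thiocarbonyl carbon. It shows that, at this position, 3-chlorophenyl can take the place of benzyl with no change that can be told apart from the ordinary scatter of repeated measurements, so compound 2 and compound 4 cannot be ranked against each other. Nothing measured here gives a reason why these two groups read alike, and this single step cannot be stretched into a rule for the position.

From the compounds shown here alone, both groups compared carry one aromatic ring of carbon only, so it stays open whether something of a different kind on this nitrogen, such as a longer alkyl chain, a primary amine or a carboxylic acid, would move the number beyond the scatter. Going by these compounds, the core also stays open: compound 1 and compound 3 each differ from compound 2 and compound 4 in more than one place, so they offer no clean comparison.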